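Methyl on the N-aryl ring of the coumarin pyrazole diesters

The source may report more compounds than this note shows. Statements on the series, on what has been measured and on what is new or still open speak of the compounds shown alone.

Two members of the series have been run so far. Compound 1 `CCOC(=O)c1c(-c2c(Cl)c3ccccc3oc2=O)nn(-c2cccc(C)c2)c1C(=O)OCC` carries a chloro substituent on its coumarin portion together with ethyl esters, and in a functional assay on DU-145 cells (Homo sapiens) for cytotoxicity, read by MTT assay, with a stated time of 48 h (a higher number here means a weaker inhibitor, a lower number a stronger inhibitor), compound 1 gives 32000 nM. Compound 2 `COC(=O)c1c(-c2cc3ccccc3oc2=O)nn(-c2ccccc2)c1C(=O)OC` has the unsubstituted coumarin, methyl esters and a plain phenyl on the pyrazole nitrogen; in this assay compound 2 gives 30000 nM. The two numbers sit within the scatter of each other, so neither compound can be called the stronger inhibitor on this evidence, and both lie in the weak range.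

Compound 3 `COC(=O)c1c(-c2cc3ccccc3oc2=O)nn(-c2cccc(C)c2)c1C(=O)OC` keeps everything of compound 2 except one change: methyl in place of hydrogen on an aromatic carbon, the aromatic carbon meta to a large group. Going by the values given here, no measured pair in the set isolates this change, so the size of the step is not known from data. Compound 1 already carries the 3-methylphenyl and does not stand apart from compound 2, which argues for a step no larger than the scatter, with no direction favoured. For compound 3 the expected step is no change at the digits printed from compound 2 to compound 3 (within the scatter). In this assay compound 3 is therefore estimated at 30000 nM, with a range from 15000 nM to 60000 nM.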

Compound 3, half-maximal inhibitory concentration: 35000 nM
Compound 3: middle estimate off by 1.2-fold (0.07 log units), on the low side, within the range that was stated.
By their numbers in this assay, from the lowest: compounds 2, 1 and 3 (each within the scatter of the next).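

In this assay, the change from phenyl to 3-methylphenyl now has a measured size of its own, a 1.2-fold higher number from compound 2 to compound 3 (0.07 log units; within the scatter), and it is read from a pair that differs in that one place only. Compound 1 could not give this reading, since it also differs from compound 2 in its chloro substituent and its ethyl esters. At this place, methyl in place of hydrogen on an aromatic carbon, meta to a large group, therefore does not separate compound 3 from compound 2, and no data shown here bear on an explanation for this result.

Still open, as far as these compounds go, is whether a group other than methyl at this place, such as an amine, a carboxylic acid or a longer chain like propyl, would give a step beyond the scatter. The steps for the chloro substituent and for ethyl in place of methyl on the esters cannot be read from these compounds, as compound 1 differs from compound 3 in more than one place.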